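This account rests on a few compounds, and the source may have more. Where it says the series, first, only, none or still open, it means among the compounds named here.

Compound 1 `CCCCN(c1nc2c(C(=O)O)cccc2o1)[C@H](C)c1ccc(-c2ccccc2-c2nnn[nH]2)cc1` is the reference point of this set. In an ADME assay on the whole organism (Macaca fascicularis) for metabolic stability, read by LC-MS, using cassette dosing, at a dose of 1 mg/kg by the oral route (on this read-out lower numbers stand for a shorter-lived compound and higher numbers for a longer-lived compound), compound 1 gives 3.7 h, which is the top of the three numbers recorded so far. Compound 2 `C[C@H](c1ccc(-c2ccccc2-c2nc(=O)o[nH]2)cc1)N(CC1CC1)c1nc2c(C(=O)O)cccc2o1` gives 2.6 h in this assay, and its gap to compound 1 is within the scatter. Within the data shown here, compound 3 `CCCCN(c1nc2c(C(=O)NC)cccc2o1)[C@H](C)c1ccc(-c2ccccc2-c2nnn[nH]2)cc1` gives 1.3 h in this assay; the step of a 2.8-fold lower number from compound 1 to compound 3 (0.45 log units; beyond the scatter) is the only single-point change measured, and it turns on the carboxy group of the shared core.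

Compound 4 `CCCCN(c1nc2c(NC(C)=O)cccc2o1)[C@H](C)c1ccc(-c2ccccc2-c2nnn[nH]2)cc1` is not yet measured. It differs from compound 1 by acetamido in place of carboxy on an aromatic carbon. Among the measured compounds shown here, no measured pair shows exactly this swap; the nearest guide is the step from compound 1 to compound 3, in which the carboxy group was likewise replaced at the same place, and the result was a modest fall beyond the scatter. On that basis a fall of comparable size is expected for compound 4, giving a step of a 2.5-fold lower number from compound 1 to compound 4 (0.39 log units; beyond the scatter). For compound 4 in this assay the estimate is 1.5 h, with a range from 0.7 h to 3.5 h.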

Compound 4, half-life: 2.2 h
The estimate for compound 4 lay 1.5-fold (0.17 log units) below the measured number, and the stated range covers the measured number.
By their numbers in this assay, from the lowest: compounds 3, 4, 2 and 1 (each within the scatter of the next, the first and the last beyond it).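

In this assay the step of a 1.7-fold lower number from compound 1 to compound 4 (0.23 log units; within the scatter) shows that losing the carboxy group from this aromatic carbon need not move the half-life beyond the scatter, which the methylcarbamoyl replacement alone had not shown. The step of a 1.7-fold higher number from compound 3 to compound 4 (0.23 log units; within the scatter) leaves acetamido and methylcarbamoyl unseparated, so the two replacements cannot be ranked on this read-out, and compound 4 cannot be told apart from either compound 1 or compound 3. Nothing measured here bears on why the half-life reads this way.

From the compounds shown here alone, whether a plain amine or a sulfonamide on this aromatic carbon would also stay within the scatter of compound 1 remains open. Also open, going by these compounds, is whether a longer chain on the acetamido carbonyl would shift the number.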